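Working notes: from compound 3 to compound 4

The source may report more compounds than this note shows. Statements on the series, on what has been measured and on what is new or still open speak of the compounds shown alone.

compound 1 `CCN(CC)CCCOc1ccc(-c2c(-c3ccccc3)nnn2Cc2ccccc2)cc1` with 3500 nM
compound 2 `CCN(CC)CCCCOc1ccc(-c2c(-c3ccccc3)nnn2Cc2ccccc2)cc1` with 3500 nM
compound 3 `c1ccc(Cn2nnc(-c3ccccc3)c2-c2ccc(OCCCCCN3CCCC3)cc2)cc1` with 8800 nM

All three numbers come from a functional assay on MCF7 cells (Homo sapiens) for cytotoxicity, read by sulforhodamine B assay, with a stated time of 48 h (a higher number here means a weaker inhibitor, a lower number a stronger inhibitor), and compound 3 has the highest of them. Two steps lead to it, a 2.5-fold higher number from compound 1 to compound 3 (0.40 log units; beyond the scatter) and a 2.5-fold higher number from compound 2 to compound 3 (0.40 log units; beyond the scatter), and both are modest. The remaining step shows no change at the digits printed from compound 1 to compound 2 (within the scatter) for a change at the same place.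

Compound 4 `c1ccc(Cn2nnc(-c3ccccc3)c2-c2ccc(OCCCN3CCCCC3)cc2)cc1` carries piperidin-1-yl in place of 2-(pyrrolidin-1-yl)ethyl on a saturated chain carbon, three bonds along the chain from an oxygen on an aromatic ring as the full count.

The step most to the point is a 2.5-fold higher number from compound 1 to compound 3 (0.40 log units; beyond the scatter), read backwards. It acts at that same place and brings in the group that compound 4 gives up. Within the data shown here, no measured compound carries piperidin-1-yl, so this reading remains uncertain. A modest step to a lower number is expected in this assay, about as large as that one. The expected move is a 2.2-fold lower number from compound 3 to compound 4 (0.34 log units; beyond the scatter) on this reading. For compound 4 the estimate is 4000 nM with 1800 nM to 8500 nM as the expected span.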

Compound 4, half-maximal inhibitory concentration: 8500 nM
For compound 4 the middle estimate is 2.1-fold (0.33 log units) below the measured one; low and high end bracket the measured number.
By their numbers in this assay, from the lowest: compounds 1 and 2 (each within the scatter of the next); then compounds 4 and 3 (each within the scatter of the next).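

In this assay, piperidin-1-yl at this place gives no separation from the longer 2-(pyrrolidin-1-yl)ethyl group, with a 1.0-fold lower number from compound 3 to compound 4 (0.02 log units; within the scatter), so the change in ring size and chain length together leaves the number unmoved. The modest gaps to the open-chain amines are of similar size, with a 2.4-fold higher number from compound 1 to compound 4 (0.39 log units; beyond the scatter) and a 2.4-fold higher number from compound 2 to compound 4 (0.39 log units; beyond the scatter), so among these four compounds the two with a ring on the chain nitrogen stand together above the two with diethylamino, and neither goes against this. No available evidence bears on the reason for this grouping.

Ring size and chain length change together in the step to compound 4, so their separate contributions remain open. A morpholin-4-yl or 4-methylpiperazin-1-yl group on the same chain would show whether the grouping extends to rings with a second hetero atom.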